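Extending a Chain by Ethyl: Expected Lipophilicity of Compound 4

A few compounds are considered here, and "the series" means these few. Any claim that something is new, unique, unknown or untested is made for them only; others in the source may bear on it.

Compound 1, `CCCCc1cccc2c(C3=C(Br)C(=O)NC3=O)c(-c3ccc(OC)cc3)[nH]c12`, gives 3.81 in a physicochemical assay for lipophilicity; a higher number here means a more lipophilic compound, a lower number a more polar compound.
Compound 2, `CCCCCCc1cccc2c(C3=C(Br)C(=O)NC3=O)c(-c3ccc(OC)cc3)[nH]c12`, gives 4.27 in this assay.
Compound 3, `CCCCOc1ccc2[nH]c(-c3cccc(OC)c3)c(C3=C(Br)C(=O)NC3=O)c2c1`, gives 3.46 in this assay.

Compounds 1 and 2 share a core and differ in one place: ethyl in place of hydrogen on a saturated chain carbon, four bonds along the chain from an aromatic carbon. That change brought a number 0.46 log units higher from compound 1 to compound 2 (beyond the scatter). Compound 3 has the lowest of the three measured numbers; compound 1 lies nearest to it, and compound 2 furthest. How the core of compound 3 differs from the core of compound 1 is not broken down here.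

Compound 4, `CCCCCCOc1ccc2[nH]c(-c3cccc(OC)c3)c(C3=C(Br)C(=O)NC3=O)c2c1`, has not been measured in this assay. It differs from compound 3 in one place: ethyl in place of hydrogen on a saturated chain carbon, four bonds along the chain from an oxygen on an aromatic ring. Compared with the change from compound 1 to compound 2, the place is not the same word for word: in compound 4 the chain carbon lies four bonds along the chain from an oxygen on an aromatic ring, whereas in compound 2 it lies four bonds along the chain from an aromatic carbon. It is therefore the same kind of change, not the same change.

The expectation for compound 4 rests on a single precedent. A step of a number 0.46 log units higher from compound 3 to compound 4 (beyond the scatter) is expected from compound 3 to compound 4, because the same kind of change gave a number 0.46 log units higher from compound 1 to compound 2 (beyond the scatter). On that basis compound 4 is expected to give about 3.92 in this assay, with a plausible range from 3.62 to 4.22.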

Compound 4, partition coefficient: 3.92
The estimate for compound 4 equals the measured number at the digits printed; low and high end bracket the measured number.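

In this assay the ethyl-for-hydrogen change gave a number 0.46 log units higher from compound 3 to compound 4 (beyond the scatter), and the same kind of change on the other core gave a number 0.46 log units higher from compound 1 to compound 2 (beyond the scatter), so the two steps agree at the printed digits. This shows that the step carried over from one core to the other in this one instance, with the chain carbon four bonds along the chain from an oxygen on an aromatic ring in one case and from an aromatic carbon in the other, but one pair set against one other pair does not make a rule for the series, and how the two cores differ is not broken down here. Nothing shown accounts for the agreement between the two steps, so it stands as an observation without an explanation.

The compounds shown leave open whether a step of this size would recur on a third core, or with the chain attached through some other kind of link. They also leave open how a longer chain such as octyl would read on either core, and whether the pattern would survive if the end of the chain carried an amine or a carboxylic acid.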